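Swapping Trifluoromethoxy for Dimethylamino in a Growth Inhibitor

A few compounds are considered here, and "the series" means these few. Any claim that something is new, unique, unknown or untested is made for them only; others in the source may bear on it.

Compound 1 `Oc1cccc2[nH]c(-c3ccc(-c4ccc(-c5ccccc5)cc4)cc3)nc12`: 41000 nM
Compound 2 `Oc1cccc2[nH]c(-c3ccc(-c4ccc(-c5ccc(OC(F)(F)F)cc5)cc4)cc3)nc12`: 2900 nM

In a functional assay on A2780 cells (Homo sapiens) for inhibition, read by sulforhodamine B assay (a higher number here means a weaker inhibitor of growth, a lower number a stronger inhibitor of growth), compound 2 gives 2900 nM, the lower number of the pair and so the stronger inhibitor of growth so far. Compound 3 `CN(C)c1ccc(-c2ccc(-c3ccc(-c4nc5c(O)cccc5[nH]4)cc3)cc2)cc1` has not yet been measured. It carries dimethylamino in place of trifluoromethoxy on an aromatic carbon, para to a large group (dimethylamino in place of trifluoromethoxy on an aromatic carbon).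

Within the data shown here, only one measured step bears on this change: a 14-fold lower number from compound 1 to compound 2 (1.15 log units; beyond the scatter). That large step put trifluoromethoxy in place of hydrogen on an aromatic carbon. Among the measured compounds shown here, no measured compound carries dimethylamino, so this single step is a thin guide. Compound 3 still has a group at this place, so a return all the way to the value of compound 1, 41000 nM, is not expected. Equally, nothing shows that dimethylamino will match trifluoromethoxy.

A modest move toward a higher number is therefore expected, estimated as a 2.1-fold higher number from compound 2 to compound 3 (0.32 log units; beyond the scatter). For compound 3 the estimated value is 6000 nM, with an expected range from 1500 nM to 25000 nM.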

Compound 3, concentration for 50% growth inhibition: 3010 nM
Beside the measured number, compound 3's estimate is 2.0-fold (0.30 log units) above it, and the stated range covers the measured number.
By their numbers in this assay, from the lowest: compounds 2 and 3 (each within the scatter of the next); then compound 1.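

In this assay, dimethylamino in place of trifluoromethoxy gives a 1.0-fold higher number from compound 2 to compound 3 (0.02 log units; within the scatter) and so the two groups cannot be told apart at this place on the ring. Dimethylamino in place of hydrogen gives a 14-fold lower number from compound 1 to compound 3 (1.13 log units; beyond the scatter) and this large step sits alongside the earlier one for trifluoromethoxy, so among these three compounds the large difference from compound 1 is now seen with two groups rather than one, and compound 3 shows that it can occur with no fluorine present, with a group of fewer heavy atoms and with nitrogen in place of oxygen as the atom joined to the ring. The numbers come with no measurement that could explain why these two groups fall so close together, or why either differs so clearly from hydrogen.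

As far as these compounds go, it remains open whether almost any group at this place would give a similar number or only some would, and a single fluorine atom, a methyl group, a carboxylic acid or a longer chain such as a butoxy group would help to test that. These three compounds also cannot show whether the match between trifluoromethoxy and dimethylamino would hold on a different core or in a different kind of cell.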